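Following an Acetyl Swap on Compound 3

The compounds below may be only part of what the source reports. "The series", "measured", "known", "first", "only" and "open" are said of these compounds alone.

compound 1 `COc1cccc(/C=C2\CCC=CC2=O)c1`: 2030 nM
compound 2 `O=C1C=CCC/C1=C\c1ccc(OC(F)(F)F)cc1`: 1040 nM
compound 3 `Cn1cc(/C=C2\CCC=CC2=O)c2ccccc21`: 6040 nM

These values come from a functional assay on MCF7 cells (Homo sapiens) for antiproliferative activity, read by sulforhodamine B assay, with a stated time of 72 h; a higher number here means a weaker inhibitor, a lower number a stronger inhibitor. Compound 3, at 6040 nM, has the highest number of the three, which makes it the weakest inhibitor here. Its gaps to compound 1 and to compound 2 both lie beyond the scatter.

Compound 4 `CC(=O)n1cc(/C=C2\CCC=CC2=O)c2ccccc21` keeps the core of compound 3 and changes one group, with acetyl in place of methyl on an aromatic nitrogen. For the measured compounds named here, no two measured compounds differ in just one place, so the data offer no direct guide to the size of this swap. The only hint is that the other compounds lie lower, with compound 1 at 2030 nM and compound 2 at 1040 nM. A small step toward a lower number in this assay is therefore expected, about the size of the scatter, though this is a weakly supported guess. The estimated change is a 1.9-fold lower number from compound 3 to compound 4 (0.28 log units; within the scatter). The expected value for compound 4 is 3200 nM, with an estimated range from 1100 nM to 9000 nM.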

Compound 4, half-maximal inhibitory concentration: 5440 nM
For compound 4 the middle estimate is 1.7-fold (0.23 log units) below the measured one, and the stated range covers the measured number.
By their numbers in this assay, from the lowest: compounds 2 and 1 (each within the scatter of the next); then compounds 4 and 3 (each within the scatter of the next).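

For the compounds shown here, this is the first pair in the set that differs in only one place, so it gives a direct reading of a change on this aromatic nitrogen. In this assay, placing acetyl where methyl stood gives a 1.1-fold lower number from compound 3 to compound 4 (0.05 log units; within the scatter), so this assay does not separate the two groups, even though acetyl is the larger group and brings a hydrogen-bond acceptor. Nothing available explains why the swap leaves the number within the scatter.

From the compounds shown here alone, it remains open whether a longer chain such as butyl, or a group carrying an amine or a carboxylic acid, would move the number on this nitrogen. Going by these compounds, compound 1 and compound 2 differ from this pair in more than one place, so what sets their numbers apart from those of compound 3 and compound 4 also stays open.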